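The compounds below may be only part of what the source reports. "The series", "measured", "known", "first", "only" and "open" are said of these compounds alone.

Measured in a functional assay on KB cells (Homo sapiens) for antiproliferative activity, read by sulforhodamine B assay, with a stated time of 72 h; on this read-out higher numbers stand for weaker inhibition and lower numbers for stronger inhibition:
- compound 1 `O=C(/C=C/c1csc2ccccc12)c1cc(Br)ccc1O`: 760 nM
- compound 2 `Cc1ccc(O)c(C(=O)/C=C/c2csc3ccccc23)c1`: 4900 nM

Of these two numbers, compound 2 has the higher, 4900 nM, which makes it the weaker inhibitor of the pair. Compound 3 `CCOc1ccc(O)c(C(=O)/C=C/c2csc3ccccc23)c1` differs from it in one place: ethoxy in place of methyl on an aromatic carbon. The group sits para to a hydroxy group.

For the measured compounds named here, only one measured step bears on this change: a 6.4-fold higher number from compound 1 to compound 2 (0.81 log units; beyond the scatter). It came from methyl in place of bromo on that same aromatic carbon, and it shows that the number in this assay can respond to a swap there. Going by the values given here, no compound with ethoxy has a measured value, so the direction remains uncertain. Given the size of that single step, only a small change is expected here. The expected result is a 1.6-fold lower number from compound 2 to compound 3 (0.21 log units; within the scatter). For compound 3 the estimate is 3000 nM, with an expected range of 800 nM to 10000 nM.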

Compound 3, half-maximal inhibitory concentration: 5800 nM
Estimate against measurement, compound 3: 1.9-fold (0.29 log units) below; the measured number falls inside the stated range.
By their numbers in this assay, from the lowest: compound 1; then compounds 2 and 3 (each within the scatter of the next).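

Putting ethoxy in place of methyl gives a 1.2-fold higher number from compound 2 to compound 3 (0.07 log units; within the scatter), so in this assay these two groups cannot be told apart, even though ethoxy has 3 heavy atoms against 1 for methyl and brings a hydrogen-bond acceptor. Ethoxy in place of bromo gives a 7.6-fold higher number from compound 1 to compound 3 (0.88 log units; beyond the scatter), beyond the scatter just as a 6.4-fold higher number from compound 1 to compound 2 (0.81 log units; beyond the scatter) was, so of the three groups at this position only bromo gives a number set apart from the others. Nothing measured here explains why these numbers fall as they do.

The compounds shown leave open how an amine, a carboxylic acid or a longer chain such as butoxy would read at this position. They also leave open whether chloro or iodo would stay close to bromo or fall in with methyl and ethoxy.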